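The source may report more compounds than this note shows. Statements on the series, on what has been measured and on what is new or still open speak of the compounds shown alone.

Measured so far:
compound 1 `CCCOc1cc(C)c(-c2cccc(CNc3ccc(OCC(=O)O)c(F)c3)c2)c(C)c1` with 38.7 nM
compound 2 `O=C(O)COc1ccc(NCc2cccc(-c3ccccc3F)c2)cc1F` with 36.5 nM
compound 3 `Cc1cc(OCCO)ccc1-c1cccc(CNc2ccc(OCC(=O)O)c(F)c2)c1` with 36.1 nM

All three compounds share the same core and were tested in a functional assay on CHO cells for agonist activity at Free fatty acid receptor 1 (Homo sapiens), read by FLIPR and calcium flux; on this read-out higher numbers stand for an effect only at larger amounts of compound and lower numbers for an effect already at smaller amounts. Compound 2 stands second highest of the three numbers, yet the three values lie so close together that none can be told apart from the others; the spread among them is within the usual scatter of such measurements.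

The next compound, compound 4 `Cc1noc(C)c1-c1cccc(CNc2ccc(OCC(=O)O)c(F)c2)c1`, changes only the aromatic tail of compound 2: 3,5-dimethyl-1,2-oxazol-4-yl in place of 2-fluorophenyl on an aromatic carbon. Going by the values given here, no measured pair shows what this kind of exchange does, so the direction of the step is open. A small loss is expected, but one that may well stay within the scatter. For compound 4 an estimated step of a 1.8-fold higher number from compound 2 to compound 4 (0.25 log units; within the scatter) is expected, giving an estimate of 65 nM with a range from 20 nM to 220 nM.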

Compound 4, half-maximal effective concentration in the Free fatty acid receptor 1 assay: 225 nM
Beside the measured number, compound 4's estimate is 3.5-fold (0.54 log units) below it; measured number above the stated range.
By their numbers in the Free fatty acid receptor 1 assay, from the lowest: compounds 3, 2 and 1 (each within the scatter of the next); then compound 4.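

In the Free fatty acid receptor 1 assay, compound 2 gives 36.5 nM and compound 4 gives 225 nM. In the Free fatty acid receptor 1 assay, this position does not accept every aromatic tail equally: 3,5-dimethyl-1,2-oxazol-4-yl in place of 2-fluorophenyl gives a 6.2-fold higher number from compound 2 to compound 4 (0.79 log units; beyond the scatter), so more compound is needed for the same effect. The heavy-atom count stays the same, while a five-membered aromatic ring with 2 hydrogen-bond acceptors enters. Nothing available explains this loss.

The same change cannot be read in a physicochemical assay for lipophilicity, read by HPLC, in phosphate buffer, measured as octanol-water partition, at pH 7.4, tested at 100 uM; on this read-out higher numbers stand for higher lipophilicity and lower numbers for lower lipophilicity: there compound 2 gives 2.36, while compound 4 has "not determined" (no result reported). Still open, going by these compounds, is how a nitrile or an amine on this aromatic carbon would compare with these two tails.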